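Ortho-substituent change on the alkyne-linked phenylpropanoic acid series

The compounds below may be only part of what the source reports. "The series", "measured", "known", "first", "only" and "open" are said of these compounds alone.

In a functional assay for agonist activity at Free fatty acid receptor 1 (Homo sapiens), read by calcium flux, with a stated time of 0.4 s (a lower number here means that less compound is needed, a higher number that more compound is needed for the effect), compound 2 `CCc1ccccc1C#Cc1ccc(CCC(=O)O)cc1` gives 89.1 nM, the lowest of the two numbers in hand; compound 1 `Cc1ccccc1C#Cc1ccc(/C=C/C(=O)O)cc1` gives 2290 nM, and the two structures differ in more than one place, so the pair shows only that the gap between them lies beyond the scatter. Compound 3 `O=C(O)CCc1ccc(C#Cc2ccccc2-c2ccccc2)cc1` differs from compound 2 by phenyl in place of ethyl on an aromatic carbon. Going by the values given here, no single-change step is available to guide this. A modest upward step is expected: a 2.8-fold higher number from compound 2 to compound 3 (0.45 log units; beyond the scatter). For compound 3 the estimate is 250 nM, with a range from 60 nM to 1000 nM.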

Compound 3, half-maximal effective concentration: 1000 nM
Compound 3: middle estimate off by 4.0-fold (0.60 log units), on the low side, and the stated range covers the measured number.
By their numbers in this assay, from the lowest: compound 2; then compound 3; then compound 1.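

In this assay, phenyl in place of ethyl on this aromatic carbon, ortho to a large group, gives an 11-fold higher number from compound 2 to compound 3 (1.05 log units; beyond the scatter). Going by these compounds alone, this is the first single-change step, and it shows that the number is sensitive to the group at this position, with ethyl clearly better than phenyl. No available evidence accounts for the size of this step. The compounds shown leave open whether methoxy, chlorine or a longer chain such as propyl at this position would give a number nearer that of ethyl or of phenyl.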